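Bromo for fluoro: a small step expected

This account rests on a few compounds, and the source may have more. Where it says the series, first, only, none or still open, it means among the compounds named here.

Compound 1 `COc1ccc(/C=C/C(=O)c2c(C)[n+]([O-])c3ccccc3[n+]2[O-])cc1` gives 27600 nM in a functional assay on CCRF-CEM cells (Homo sapiens) for inhibition, with a stated time of 3 days; on this read-out lower numbers stand for stronger inhibition and higher numbers for weaker inhibition.
Compound 2 `Cc1c(C(=O)/C=C/c2ccc(Cl)c(Cl)c2)[n+]([O-])c2ccccc2[n+]1[O-]` gives 15400 nM in this assay.
Compound 3 `Cc1c(C(=O)/C=C/c2ccc(F)cc2)[n+]([O-])c2ccccc2[n+]1[O-]` gives 10000 nM in this assay.

Compound 3 has the lowest number of the three. One step that reaches it is a 1.5-fold lower number from compound 2 to compound 3 (0.19 log units; within the scatter), which is within the scatter, so those two cannot be ranked against each other. The other step that reaches it is a 2.8-fold lower number from compound 1 to compound 3 (0.44 log units; beyond the scatter), a modest but real difference.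

Compound 4 `Cc1c(C(=O)/C=C/c2ccc(Br)cc2)[n+]([O-])c2ccccc2[n+]1[O-]` differs from compound 3 by bromo in place of fluoro on an aromatic carbon of a six-membered aromatic ring of carbon only, para to a large group. For the measured compounds named here, no measured step swaps one halogen for another at this spot. The nearest guides are the move from the dichloro pattern to the single fluoro, a 1.5-fold lower number from compound 2 to compound 3 (0.19 log units; within the scatter), and the move from methoxy to fluoro, a 2.8-fold lower number from compound 1 to compound 3 (0.44 log units; beyond the scatter); neither was large. Compound 4 is therefore expected to show only a 1.1-fold higher number from compound 3 to compound 4 (0.04 log units; within the scatter), a step not beyond the scatter. The estimate for compound 4 in this assay is 11000 nM, with a range from 5000 nM to 25000 nM.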

Compound 4, half-maximal inhibitory concentration: 11600 nM
Estimate against measurement, compound 4: 1.1-fold (0.02 log units) below; the measured number falls inside the stated range.
By their numbers in this assay, from the lowest: compounds 3, 4, 2 and 1 (each within the scatter of the next, the first and the last beyond it).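

In this assay, for the compounds shown here, the first direct swap of one halogen for another at this spot gives a 1.2-fold higher number from compound 3 to compound 4 (0.06 log units; within the scatter) and so leaves fluoro and bromo indistinguishable on this aromatic carbon, para to a large group. The single bromo likewise cannot be separated from the 3,4-dichlorophenyl pattern, with a 1.3-fold lower number from compound 2 to compound 4 (0.12 log units; within the scatter) as the step, whereas bromo in place of methoxy gives a 2.4-fold lower number from compound 1 to compound 4 (0.38 log units; beyond the scatter) as a modest but real difference, much like a 2.8-fold lower number from compound 1 to compound 3 (0.44 log units; beyond the scatter) seen with fluoro; compound 2 goes against any simple split between halogens and methoxy, since a 1.8-fold lower number from compound 1 to compound 2 (0.25 log units; within the scatter) stays within the scatter. No measurement is available that would explain these results.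

All the groups shown at this end of the molecule are halogens or methoxy, so it remains open whether an amine or a carboxylic acid at the same spot would move the number beyond the scatter from compound 3. Also open, from the compounds shown here alone, is what a longer chain in place of the methyl on the shared core would do, since that methyl stays the same in all four compounds.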